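A few compounds are considered here, and "the series" means these few. Any claim that something is new, unique, unknown or untested is made for them only; others in the source may bear on it.

Compound 1 `CCCCc1oc2ccccc2c1C(=O)c1ccc(OCC(N)=O)cc1` carries a carbamoylmethyl group on its shared core. Among the measured compounds shown here, in a functional assay on U-937 cells (Homo sapiens) for antiproliferative activity, read by MTT assay, with a stated time of 24 h (on this read-out higher numbers stand for weaker inhibition and lower numbers for stronger inhibition), compound 1 gives 42200 nM, the highest of the three numbers measured so far, though both others sit within the scatter of it. Compound 2 `CCCCc1oc2ccccc2c1C(=O)c1ccc(OCC(=O)N2CCCC2)cc1` gives 32500 nM and compound 3 `CCCCc1oc2ccccc2c1C(=O)c1ccc(OCC(=O)N2CCCCC2)cc1` gives 37100 nM. The steps of a 1.3-fold lower number from compound 1 to compound 2 (0.11 log units; within the scatter) and a 1.1-fold lower number from compound 1 to compound 3 (0.06 log units; within the scatter) stay within the scatter, as does a 1.1-fold higher number from compound 2 to compound 3 (0.06 log units; within the scatter). Compound 4 `CCCCc1oc2ccccc2c1C(=O)c1ccc(OCC(=O)NCc2ccccc2)cc1` differs from compound 1 by benzyl in place of hydrogen on an amide-type nitrogen, a change on the amide-type nitrogen rather than on the carbonyl carbon. Because a 1.3-fold lower number from compound 1 to compound 2 (0.11 log units; within the scatter) and a 1.1-fold lower number from compound 1 to compound 3 (0.06 log units; within the scatter) both stay within the scatter while altering the same amide end, no step beyond the scatter is expected for compound 4 either. Compound 4 is therefore estimated at 35000 nM, within 15000 nM to 80000 nM, an expected step of a 1.2-fold lower number from compound 1 to compound 4 (0.08 log units; within the scatter).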

Compound 4, half-maximal inhibitory concentration: 16300 nM
The estimate for compound 4 lay 2.1-fold (0.33 log units) above the measured number; the measured number falls inside the stated range.
By their numbers in this assay, from the lowest: compounds 4, 2, 3 and 1 (each within the scatter of the next, the first and the last beyond it).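

Among the compounds shown here, in this comparison, the amide end is no longer flat: benzyl on the amide-type nitrogen gives a 2.6-fold lower number from compound 1 to compound 4 (0.41 log units; beyond the scatter) in this assay, the first step in this set beyond the scatter. Set against the ring amides, benzylamino gives a 2.3-fold lower number from compound 3 to compound 4 (0.36 log units; beyond the scatter) and a 2.0-fold lower number from compound 2 to compound 4 (0.30 log units; within the scatter), so compound 4 separates modestly from compound 3 but not from compound 2. No measurement here gives a reason for these steps. Going by these compounds, it remains open whether the aromatic ring of benzyl matters, which cyclohexylmethyl on the same nitrogen would address. On these data alone, a longer chain such as 2-phenylethyl also remains open.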